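This account rests on a few compounds, and the source may have more. Where it says the series, first, only, none or still open, it means among the compounds named here.

Of the compounds shown here, three from this series have been tested in an ADME assay on NIH3T3 cells (Mus musculus) for cytotoxicity, read by MTT assay, with a stated time of 24 h; on this read-out higher numbers stand for weaker inhibition and lower numbers for stronger inhibition. Compound 1 `COc1ccc(N2CCN(CC(=O)N3CCN(c4nnc(-c5ccc(C)cc5)c(-c5ccc(C)cc5)n4)CC3)CC2)cc1` gives 116000 nM in this assay. Compound 2 `Cc1ccc(-c2nnc(N3CCN(C(=O)CN4CCN(c5ccc(Cl)cc5)CC4)CC3)nc2-c2ccc(C)cc2)cc1` gives 567000 nM. The step between them, a 4.9-fold higher number from compound 1 to compound 2 (0.69 log units; beyond the scatter), goes with a single change, (chloro in place of methoxy on an aromatic carbon).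

Compound 3 `COc1ccc(-c2nnc(N3CCN(C(=O)CN4CCN(c5cccc(OC)c5)CC4)CC3)nc2-c2ccc(OC)cc2)cc1` is built on a different core, and the difference between the two cores is not broken down here. Compound 3 in this assay reaches only a limit of the assay, > 821000 nM, so no number is known for it. That is the case described by the limit of > 821000 nM in this assay, at which 1 of the 3 values shown sits.

Compound 4 `COc1ccc(-c2nnc(N3CCN(C(=O)CN4CCN(c5cccc(Cl)c5)CC4)CC3)nc2-c2ccc(OC)cc2)cc1` has not yet been measured. It differs from compound 3 by chloro in place of methoxy on an aromatic carbon. For the measured compounds named here, this is the same kind of change as the one from compound 1 to compound 2, but the surroundings differ: in compound 2 the chloro sits para to a large group, whereas in compound 4 it sits meta to a large group. Going by the values given here, since compound 3 already stands at a limit of the assay, and the one measured example of this kind of change moved the number upward, compound 4 is expected to move by roughly a step that the limit leaves unreadable from compound 3 to compound 4, most likely landing again at a limit rather than a number. The estimate for compound 4 in this assay is 1500000 nM, with a range from 400000 nM to 5000000 nM.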

Compound 4, half-maximal inhibitory concentration: > 814000 nM
Compound 4 was reported as a limit; the forecaster's own chance of this, stated with the estimate: 75%; the middle value lies beyond the limit too.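

In this assay compound 4 gives > 814000 nM, which is a limit of the assay and not a number. Compound 3 gives > 821000 nM, also a limit, so the change from 3-methoxyphenyl to 3-chlorophenyl between compound 3 and compound 4 cannot be read as a step. The compounds shown leave open how far this change moves the read-out on the core these two compounds share.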